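Removing the Hydroxyl From the Side Chain of Compound 3

This account rests on a few compounds, and the source may have more. Where it says the series, first, only, none or still open, it means among the compounds named here.

In a functional assay on HL-60 cells (Homo sapiens) for cytotoxicity, read by WST assay, with a stated time of 48 h (on this read-out higher numbers stand for weaker inhibition and lower numbers for stronger inhibition), compound 3, `COc1cc(C(c2ccc(O)c(OC)c2)[C@@H](C)[C@@H](C)CO)ccc1O`, reaches only a limit of the assay, > 100000 nM. Compound 1, `COC[C@@H](C(C)C)C(c1ccc(O)c(OC)c1)c1ccc(O)c(OC)c1`, gives 54000 nM in this assay, and compound 2, `COc1cc(C(c2ccc(O)c(OC)c2)[C@H](C)[C@H](C)CF)ccc1O`, gives 56000 nM. The step of an at least 1.8-fold higher number from compound 1 to compound 3 (0.26 log units; that floor lies within the scatter) and the step of an at least 1.7-fold higher number from compound 2 to compound 3 (0.25 log units; that floor lies within the scatter) therefore carry only floors, and both rest on (the limit of > 100000 nM in this assay, at which 1 of the 3 values shown sits).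

Compound 4, `COc1cc(C(c2ccc(O)c(OC)c2)[C@@H](C)C(C)C)ccc1O`, differs from compound 3 by hydrogen in place of hydroxy on a saturated chain carbon, four bonds along the chain from two aromatic carbons. For the measured compounds named here, no measured pair shows exactly this change. The closest measured step, an at least 1.7-fold higher number from compound 2 to compound 3 (0.25 log units; that floor lies within the scatter), brought hydroxymethyl in place of fluoromethyl and moved the number up to the limit; the change to compound 4 runs the other way, taking the hydroxy out entirely. Compound 1 and compound 2, both without a hydroxy, sit within the scatter of each other, so the expectation is a return to that range rather than a further loss. The step of an at least 1.6-fold lower number from compound 3 to compound 4 (0.22 log units; that floor lies within the scatter) is expected as a move back from the limit toward stronger inhibition. Compound 4 is therefore estimated at about 60000 nM, with a plausible range from 25000 nM to 150000 nM.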

Compound 4, half-maximal inhibitory concentration: 20000 nM
For compound 4 the middle estimate is 3.0-fold (0.48 log units) above the measured one; the measured number lies below the stated range.
By their numbers in this assay, from the lowest: compound 4; then compounds 1 and 2 (each within the scatter of the next). At a limit, above all of these: compound 3.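

In this assay taking the hydroxy off gives a step that, unlike the earlier ones, clears the scatter: an at least 5.0-fold lower number from compound 3 to compound 4 (0.69 log units; beyond the scatter) is a floor and not a full size, since one end of it is a limit: the limit of > 100000 nM in this assay, at which 1 of the 4 values shown sits.

The bare 1,2-dimethylpropyl chain also separates from the two side chains that carry no hydroxy, with a 2.8-fold lower number from compound 2 to compound 4 (0.45 log units; beyond the scatter) on losing the fluorine and a 2.7-fold lower number from compound 1 to compound 4 (0.43 log units; beyond the scatter) on swapping methoxy for hydrogen. Among these four compounds, then, losing the hydroxy goes beyond a return to the level of the fluoromethyl and methoxymethyl chains, and the chain with no oxygen or fluorine has the lowest number.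

From the compounds shown here alone, the value of compound 3 remains a limit, so the full size of the hydroxy step stays open. Also open, going by these compounds, is how an amine, a carboxylic acid or a longer chain at this chain end would read.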